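The source may report more compounds than this note shows. Statements on the series, on what has been measured and on what is new or still open speak of the compounds shown alone.

In a functional assay on U-87MG ATCC cells (Homo sapiens) for inhibition (a higher number here means a weaker inhibitor, a lower number a stronger inhibitor), compound 1 `COc1cc(/C=C/C(=O)c2cccc(NC(=O)c3c(Cl)cccc3Cl)c2)ccc1O` gives 17.8 ug/mL. Compound 2 `COc1cc(/C=C/C(=O)c2cccc(NC(=O)c3ccc(Cl)cc3)c2)ccc1O` is reported only as a limit, > 50 ug/mL. Compound 3 `COc1cc(/C=C/C(=O)c2cccc(NC(=O)c3ccc(Cl)cc3Cl)c2)ccc1O` is likewise reported only as a limit, > 50 ug/mL, so its place on the scale has no number. The change to compound 4 `CCCC(=O)Nc1cccc(C(=O)/C=C/c2ccc(O)c(OC)c2)c1` puts propyl in place of 2,4-dichlorophenyl on a carbonyl carbon.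

Three measured steps alter the group on this carbonyl carbon. They are an at least 2.8-fold higher number from compound 1 to compound 2 (0.44 log units; beyond the scatter) and an at least 2.8-fold higher number from compound 1 to compound 3 (0.44 log units; beyond the scatter), both beyond the scatter, and a step that the two limits leave unreadable from compound 2 to compound 3. None of them replaces the aromatic ring with a chain, so they bear on the new change only indirectly. Only compound 1 at 17.8 ug/mL gave a number, and the other two sit at the limit of > 50 ug/mL in this assay, at which 2 of the 3 values shown sit. A large step in this assay is therefore not expected, and its direction cannot be read from these data. The expected change is an at least 1.1-fold lower number from compound 3 to compound 4 (0.04 log units; that floor lies within the scatter). For compound 4 the estimated value is 45 ug/mL, with an expected range from 20 ug/mL to 90 ug/mL.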

Compound 4, half-maximal inhibitory concentration: 5.56 ug/mL
Compound 4: the middle estimate sits 8.1-fold (0.91 log units) above what was measured; measured number outside the range, below it.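

With propyl on the carbonyl carbon, the series gains its strongest inhibitor in this assay, and an aromatic ring proves unnecessary at this position, with the step being a 3.2-fold lower number from compound 1 to compound 4 (0.51 log units; beyond the scatter). Replacing 2,4-dichlorophenyl gives an at least 8.9-fold lower number from compound 3 to compound 4 (0.95 log units; beyond the scatter), and replacing 4-chlorophenyl gives an at least 8.9-fold lower number from compound 2 to compound 4 (0.95 log units; beyond the scatter). These last two steps are floors and not full sizes, as each starts from a value that is only a limit: the limit of > 50 ug/mL in this assay, at which 2 of the 4 values shown sit.

Only one chain is shown, so it remains open whether this result is particular to propyl or extends to other chains, such as a longer butyl chain or a chain ending in an amine or a carboxylic acid. The reason for the step also stays open: no property of these groups is given as measured.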